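Methoxy Addition on a Cytotoxicity-Screened Hydrazone Pair

The source may hold more compounds than are shown below. What is called first, only, known or untested is meant among the compounds shown, and "the series" means these compounds.

Compound 1 `COc1ccc(/C=N/NC(=O)c2ccc(-c3ccc(Cl)cc3)nc2C)cc1OC`: 443 ug/mL
Compound 2 `COc1ccc(/C=N/NC(=O)c2ccc(-c3cccc(Cl)c3)nc2C)cc1`: 500 ug/mL

In an ADME assay on WI-38 cells (Homo sapiens) for cytotoxicity, read by colorimetric assay and crystal violet staining, with a stated time of 24 h (a lower number here means a stronger inhibitor, a higher number a weaker inhibitor), compound 1 gives 443 ug/mL, while compound 2 gives 500 ug/mL; the two numbers lie within the scatter of each other, so neither compound stands apart. Compound 3 `COc1cc(/C=N/NC(=O)c2ccc(-c3ccc(Cl)cc3)nc2C)cc(OC)c1OC` differs from compound 1 by methoxy in place of hydrogen on an aromatic carbon. For the measured compounds named here, no measured pair shows what such a change does here, so the step of a 1.0-fold higher number from compound 1 to compound 3 (0.01 log units; within the scatter) is expected to stay within the scatter. Compound 3 is therefore estimated at 450 ug/mL, with a range from 250 ug/mL to 800 ug/mL.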

Compound 3, half-maximal inhibitory concentration: 41.1 ug/mL
For compound 3 the middle estimate is 11-fold (1.04 log units) above the measured one; measured number below the stated range.
By their numbers in this assay, from the lowest: compound 3; then compounds 1 and 2 (each within the scatter of the next).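

In this assay a methoxy in place of hydrogen on this aromatic carbon, ortho to a methoxy group and meta to a large group, gives an 11-fold lower number from compound 1 to compound 3 (1.03 log units; beyond the scatter) and so shows that this one position can carry a large change. Compounds 1 and 2 alone, lying within the scatter of each other, gave no sign of this. Nothing available accounts for the size of the step.

On these data alone, what stays open is whether methoxy itself is required at this position. A hydroxyl, a fluorine or an ethoxy group there, read against compound 3, would settle that.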